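Swapping a Fluorophenyl for a Chlorophenyl Group

The compounds below may be only part of what the source reports. "The series", "measured", "known", "first", "only" and "open" are said of these compounds alone.

Compound 2 `Fc1ccc(N2CCN(Cn3nc(-c4ccc5c(c4)OCCO5)oc3=S)CC2)cc1` carries a 4-fluorophenyl group on an amine nitrogen in a ring of the shared core. In a functional assay on SW 1116 cells (Homo sapiens) for antiproliferative activity, read by MTT assay, with a stated time of 48 h (on this read-out lower numbers stand for stronger inhibition and higher numbers for weaker inhibition), compound 2 gives only a limit, > 50000 nM, which is the limit of > 50000 nM in this assay, at which 1 of the 2 values shown sits, rather than a measured number. Compound 1 `COc1ccccc1N1CCN(Cn2nc(-c3ccc4c(c3)OCCO4)oc2=S)CC1` bears a 2-methoxyphenyl group in the same place and gives 16900 nM in this assay. Going by the values given here, the only measured comparison at this position is an at least 2.9-fold higher number from compound 1 to compound 2 (0.47 log units; beyond the scatter), a change in which the group and its substitution both differ at once.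

Compound 3 `S=c1oc(-c2ccc3c(c2)OCCO3)nn1CN1CCN(c2ccccc2Cl)CC1` has not yet been measured. It differs from compound 2 by 2-chlorophenyl in place of 4-fluorophenyl on an amine nitrogen in a ring. Among the compounds with values here, no measured step covers this exact change; the known step from compound 1 to compound 2 weakens activity when the 2-methoxyphenyl is replaced, and compound 3 returns to a 2-substituted phenyl while keeping a halogen. On that basis the step of an at least 1.6-fold lower number from compound 2 to compound 3 (0.22 log units; that floor lies within the scatter) is expected to be small and could leave compound 3 again at the limit. The estimated value for compound 3 in this assay is 30000 nM, within a range from 10000 nM to 80000 nM.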

Compound 3, half-maximal inhibitory concentration: > 50000 nM
Compound 3 ended at the assay's limit; the forecaster's own chance of this, stated with the estimate: 40%; at least 1.6-fold (0.22 log units) between middle value and limit.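

Compound 3 separates two changes that were mixed together in the earlier comparison: 2-chlorophenyl and 2-methoxyphenyl differ only by chloro in place of methoxy on an aromatic carbon, and that single change gives an at least 2.9-fold higher number from compound 1 to compound 3 (0.47 log units; beyond the scatter) in this assay. A 2-substituted phenyl on this ring nitrogen is therefore not enough on its own to give a measurable value, and of the three compounds shown only compound 1, with its 2-methoxyphenyl group, gives a number rather than a limit. The step between compound 2 and compound 3 cannot be read, because both values are limits and not numbers: the limit of > 50000 nM in this assay, at which 2 of the 3 values shown sit.

The compounds shown leave open whether the value of compound 1 depends on the methoxy group itself or would also appear with a close relative such as 2-ethoxyphenyl or 2-hydroxyphenyl. They also leave open how a methoxy group elsewhere on the phenyl ring, as in 4-methoxyphenyl, or a plain unsubstituted phenyl would read out on this shared core.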